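Cyclohexylmethyl replacing cyanophenyl on the imidazole chain

The source may hold more compounds than are shown below. What is called first, only, known or untested is meant among the compounds shown, and "the series" means these compounds.

Compound 3 `N#Cc1ccc(Cc2cnc(CCc3ccc(-c4ccccc4C(=O)O)cc3)[nH]2)cc1` gives 723 nM in an in vitro functional assay on cells for agonist activity at Bombesin receptor subtype-3 (Mus musculus), read by luminescence and calcium flux (on this read-out lower numbers stand for an effect already at smaller amounts and higher numbers for an effect only at larger amounts of compound), the highest of the three numbers measured. Compound 2 `COc1ccc(Cc2cnc(CCc3ccc(-c4ccccc4C(=O)O)cc3)[nH]2)cc1` gives 513 nM, and the step of a 1.4-fold higher number from compound 2 to compound 3 (0.15 log units; within the scatter) lies within the scatter. Compound 1 `O=C(O)c1ccccc1-c1ccc(CCc2ncc(CC3CCCCC3)[nH]2)cc1` gives 7.3 nM, so compound 1 stands far from compound 3.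

Compound 4 `O=C(O)c1ccccc1-c1ccc(CCc2ncc(CCC3CCCCC3)[nH]2)cc1` differs from compound 3 by cyclohexylmethyl in place of 4-cyanophenyl on a saturated chain carbon bound to an aromatic carbon. The measured steps that bear on this change run the other way: a 99-fold higher number from compound 1 to compound 3 (2.00 log units; beyond the scatter) and a 70-fold higher number from compound 1 to compound 2 (1.85 log units; beyond the scatter). Both show that replacing a saturated ring with an aromatic one at this position raises the number strongly, so returning to a saturated ring is expected to lower it by a comparable amount. Going by the values given here, compound 4 carries one more chain carbon than compound 1, for which no measured step exists, so some uncertainty remains. Compound 4 is therefore expected to give 20 nM, within a range from 5 nM to 100 nM. This estimate is expected to mean a 36-fold lower number from compound 3 to compound 4 (1.56 log units; beyond the scatter).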

Compound 4, half-maximal effective concentration: 33 nM
Compound 4: the middle estimate sits 1.7-fold (0.22 log units) below what was measured; the range from low to high includes it.
By their numbers in this assay, from the lowest: compound 1; then compound 4; then compounds 2 and 3 (each within the scatter of the next).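

In this assay, a saturated ring on the saturated chain carbon again gives much lower numbers than the substituted aromatic rings (a 22-fold lower number from compound 3 to compound 4 (1.34 log units; beyond the scatter); a 16-fold lower number from compound 2 to compound 4 (1.19 log units; beyond the scatter)), so the low numbers at this position do not belong to the cyclohexyl of compound 1 alone. Going by these compounds alone, the first reading of chain length on the saturated ring is smaller but still beyond the scatter (a 4.5-fold higher number from compound 1 to compound 4 (0.66 log units; beyond the scatter)), so cyclohexylmethyl in place of cyclohexyl keeps most of the gain over the aromatic rings. Nothing given here explains these differences.

Ring type and chain length change together from the aromatic compounds to compound 4, and a 2-phenylethyl group would separate the two. On these data alone, how a 3-cyclohexylpropyl group, a cyclopentyl ring or an amine on the chain would read at this position remains open.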